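Chain homologation toward compound 3

A few compounds are considered here, and "the series" means these few. Any claim that something is new, unique, unknown or untested is made for them only; others in the source may bear on it.

Compound 1 `O=C(CCCCc1[nH]c2ccccc2c1C1=C(Br)C(=O)NC1=O)Nc1ccccc1` and compound 2 `O=C(CCCCCc1[nH]c2ccccc2c1C1=C(Br)C(=O)NC1=O)Nc1ccccc1` share a core and differ only in chain length. In a physicochemical assay for lipophilicity (a higher number here means a more lipophilic compound, a lower number a more polar compound), compound 1 gives 2.56, and compound 2 gives 2.68. For the measured compounds named here, the one step measured, a number 0.12 log units higher from compound 1 to compound 2 (within the scatter), falls within the scatter, so compound 2 sits essentially level with compound 1 on this assay, with no other comparator.

Compound 3 `O=C(CCCCCCc1[nH]c2ccccc2c1C1=C(Br)C(=O)NC1=O)Nc1ccccc1` carries the same kind of change one position further out: (phenylcarbamoyl)methyl in place of phenylcarbamoyl on a saturated chain carbon, five bonds along the chain from an aromatic carbon. Going by the values given here, the only step that bears on this is the earlier homologation, a number 0.12 log units higher from compound 1 to compound 2 (within the scatter), which was small. A step of similar size and direction is therefore expected from compound 2 to compound 3, that is a number 0.12 log units higher from compound 2 to compound 3 (within the scatter), again not clearly beyond the scatter. Compound 3 is accordingly estimated at 2.8 in this assay, within a range of 2.55 to 3.05.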

Compound 3, partition coefficient: 2.85
Compound 3: the middle estimate sits 0.05 log units below what was measured; measured number inside the range.
By their numbers in this assay, from the lowest: compounds 1, 2 and 3 (each within the scatter of the next).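

In this assay, (phenylcarbamoyl)methyl in place of phenylcarbamoyl on a saturated chain carbon, five bonds along the chain from an aromatic carbon, gives a number 0.17 log units higher from compound 2 to compound 3 (within the scatter), so at this position too the change leaves the pair level within the scatter. The series now holds two single homologation steps, this one and a number 0.12 log units higher from compound 1 to compound 2 (within the scatter), and neither separates its pair of compounds. Nothing available here accounts for the size of either step.

Open, as far as these compounds go, is whether a longer chain than that of compound 3 would give a step beyond the scatter. Also open, from the compounds shown here alone, is how a carboxylic acid or an amine in place of phenylcarbamoyl at the chain end would read in this assay.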